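Removing the Amino Group from a Chloropurine Benzyl Derivative

This account rests on a few compounds, and the source may have more. Where it says the series, first, only, none or still open, it means among the compounds named here.

Measured compounds:
- Compound 1, `Nc1nc(Cl)c2ncn(Cc3ccccc3CCl)c2n1`: 18600 nM
- Compound 2, `Nc1nc(Cl)c2ncn(Cc3cccc(CCl)c3)c2n1`: 10700 nM

In a functional assay on SK-MEL-2 cells (Homo sapiens) for cytotoxicity, read by sulforhodamine B assay, with a stated time of 48 h (a higher number here means a weaker inhibitor of growth, a lower number a stronger inhibitor of growth), compound 1 gives 18600 nM, the highest of the two numbers recorded. Its nearest neighbour is compound 2, which in this assay gives 10700 nM; the two values lie within the scatter, so no order between them can be claimed. Both compounds act only weakly on growth of these cells.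

Compound 3, `ClCc1ccccc1Cn1cnc2c(Cl)ncnc21`, has not been measured yet. It differs from compound 1 in a single place: hydrogen in place of amino on an aromatic carbon. Among the measured compounds shown here, no pair of measured compounds shows the effect of this change, so the size of the step is uncertain. Given that the shared core stays in place and the substituent on the aromatic ring is unchanged, the expected step of a 1.3-fold higher number from compound 1 to compound 3 (0.13 log units; within the scatter) is small, possibly no larger than the scatter, with a slight lean toward a higher number. Compound 3 is therefore estimated at 25000 nM, in a range from 8000 nM to 80000 nM.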

Compound 3, concentration for 50% growth inhibition: 2750 nM
Compound 3: middle estimate off by 9.1-fold (0.96 log units), on the high side; measured number below the stated range.
By their numbers in this assay, from the lowest: compound 3; then compounds 2 and 1 (each within the scatter of the next).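

Taking the amino group away from the aromatic carbon between two ring nitrogen atoms, leaving hydrogen there, gives a 6.8-fold lower number from compound 1 to compound 3 (0.83 log units; beyond the scatter) in this assay and this step lies beyond the scatter. This position therefore matters for growth inhibition in these cells, and in this pair the amino group is not needed for the effect: the compound without it is the stronger inhibitor. Nothing at hand explains why this change lowers the number.

Among the compounds shown here, only this one pair shows the step, so it remains open whether the same change would lower the number for compound 2 as well. Also open, from the compounds shown here alone, is how a methylamino group or a hydroxyl group on this carbon would compare with amino and hydrogen.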